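This account rests on a few compounds, and the source may have more. Where it says the series, first, only, none or still open, it means among the compounds named here.

Within the data shown here, in a physicochemical assay for solubility, read by HPLC, with a stated time of 24 h (on this read-out lower numbers stand for lower solubility and higher numbers for higher solubility), compound 2 `CC(C)(C)c1[nH]cnc1/C=c1\[nH]c(=O)/c(=C/c2cccc(C(=O)N3CCC3)c2)[nH]c1=O` gives 4.23 ug/mL as the only actual number so far. Compound 1 `O=C(c1ccccc1)c1cccc(/C=c2\[nH]c(=O)/c(=C/c3ccccn3)[nH]c2=O)c1` reports < 0.1 ug/mL as a limit of the assay and not a number.

Compound 3 `CC(C)(C)c1[nH]cnc1/C=c1\[nH]c(=O)/c(=C/c2cccc(C(=O)c3ccncc3)c2)[nH]c1=O` has pyridin-4-yl in place of azetidin-1-yl on a carbonyl carbon and is otherwise the same as compound 2. Among the measured compounds shown here, no measured pair shows this swap on its own, so any forecast is uncertain. Compound 1 also carries an aromatic ring on a carbonyl carbon, and its limit of < 0.1 ug/mL is the sole pointer, although it differs elsewhere too. A drop beyond the usual scatter is expected, with the estimated step of a 5.3-fold lower number from compound 2 to compound 3 (0.72 log units; beyond the scatter) as its size. In this assay the expected value for compound 3 is 0.8 ug/mL within an estimated range of 0.15 ug/mL to 4 ug/mL for repeated measurements.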

Compound 3, solubility: < 0.1 ug/mL
Compound 3 ended at the assay's limit (the forecaster's own chance of this, stated with the estimate: 15%); middle value at least 8.0-fold (0.90 log units) away from the limit.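

Among these compounds, putting pyridin-4-yl in place of azetidin-1-yl on a carbonyl carbon gives, in this assay, an at least 42-fold lower number from compound 2 to compound 3 (1.62 log units; beyond the scatter), the first comparison here in which only one place changes. The value of compound 3 is a limit of the assay and not a number. Among the compounds shown here, compound 1 also carries an aromatic ring on a carbonyl carbon but differs elsewhere too, so only this pair ties the fall to the group on the carbonyl carbon alone.

Open, going by these compounds, is how a dimethylamino group or a piperidin-1-yl ring on the same carbonyl carbon would read, which would help separate the effect of the amide link from that of the ring attached to the carbonyl. Compounds sitting at the limit also cannot be ranked against one another: the limit of < 0.1 ug/mL in this assay, at which 2 of the 3 values shown sit.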